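The compounds below may be only part of what the source reports. "The series", "measured", "known", "first", "only" and "open" are said of these compounds alone.

Working notes on the series. In a functional assay (aorta) with Oryctolagus cuniculus as the target (on this read-out higher numbers stand for weaker binding and lower numbers for tighter binding), compound 1 (`COc1cc(C(C)=O)ccc1OCCCN1CCC(C(c2ccc(F)cc2)c2ccc(F)cc2)CC1`) gives 1.59 nM, compound 2 (`COc1cc(C(C)=O)ccc1OCCCN1CCC(C(c2cccc(F)c2)c2cccc(F)c2)CC1`) gives 3.16 nM and compound 3 (`COc1cc(C(C)=O)ccc1OCCCN1CCC(C(c2ccc(Cl)cc2)c2ccc(Cl)cc2)CC1`) gives 2.51 nM. These three values lie within the scatter of one another, so compound 1 has no distinct place among them. Compound 4 (`COc1cc(C(C)=O)ccc1OCCCN1CCC(Cc2ccc(F)cc2)CC1`) differs from compound 1 by a single change: hydrogen in place of 4-fluorophenyl on a saturated chain carbon bound to an aromatic carbon and a saturated ring carbon. Among the measured compounds shown here, no measured pair shows this kind of change, so the size rests on judgement alone. A moderate move to a higher number in this assay, beyond the scatter, is expected. The estimated step is a 7.5-fold higher number from compound 1 to compound 4 (0.88 log units; beyond the scatter). For compound 4 the estimated value is 12 nM, with an expected range of 3 nM to 50 nM.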

Compound 4, dissociation constant: 20 nM
For compound 4 the middle estimate is 1.7-fold (0.22 log units) below the measured one; the measured number falls inside the stated range.
By their numbers in this assay, from the lowest: compounds 1, 3 and 2 (each within the scatter of the next); then compound 4.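

In this assay, among the compounds shown here, hydrogen in place of 4-fluorophenyl on a saturated chain carbon bound to an aromatic carbon and a saturated ring carbon gives a 13-fold higher number from compound 1 to compound 4 (1.10 log units; beyond the scatter) and is the only single change with a step read so far. This position therefore matters to the read-out: removing one 4-fluorophenyl gives a large move, even though compound 4 keeps the other. Nothing at hand accounts for the size of this step. On these data alone, it remains open whether a methyl, a hydroxyl or an unsubstituted phenyl at this carbon would keep the number close to that of compound 1.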